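This account rests on a few compounds, and the source may have more. Where it says the series, first, only, none or still open, it means among the compounds named here.

In a functional assay on A549 cells (Homo sapiens) for antiproliferative activity, read by MTT assay, with a stated time of 72 h (on this read-out higher numbers stand for weaker inhibition and lower numbers for stronger inhibition), three compounds have values so far:
- Compound 1 (`COc1ccc(-c2c(C(=O)c3cc(OC)c(OC)c(OC)c3)sc3ccccc23)cc1`) gives 4400 nM
- Compound 2 (`COc1cc(C(=O)c2sc3ccccc3c2-c2ccc(SC)cc2)cc(OC)c1OC`) gives 5400 nM
- Compound 3 (`COc1cc(C(=O)c2sc3ccccc3c2Nc2ccccc2)cc(OC)c1OC`) gives 3000 nM

Compound 3 cannot be told apart from the other two, as both a 1.5-fold lower number from compound 1 to compound 3 (0.17 log units; within the scatter) and a 1.8-fold lower number from compound 2 to compound 3 (0.26 log units; within the scatter) show. Compound 4 (`COc1ccc(Nc2c(C(=O)c3cc(OC)c(OC)c(OC)c3)sc3ccccc23)cc1`) differs from compound 3 in one place, with methoxy in place of hydrogen on an aromatic carbon. Going by the values given here, no measured pair makes exactly this change. The closest evidence is a 1.2-fold higher number from compound 1 to compound 2 (0.09 log units; within the scatter) for a swap of methoxy for methylsulfanyl, together with the two small steps to compound 3 above. All three are small, so no step beyond the scatter is expected in this assay here. The estimate amounts to an expected 1.2-fold lower number from compound 3 to compound 4 (0.08 log units; within the scatter) in this series. Compound 4 is expected near 2500 nM with an estimated range from 700 nM to 6500 nM for its measurement.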

Compound 4, half-maximal inhibitory concentration: 9300 nM
Compound 4: the middle estimate sits 3.7-fold (0.57 log units) below what was measured; the measured number lies above the stated range.
By their numbers in this assay, from the lowest: compounds 3, 1, 2 and 4 (each within the scatter of the next, the first and the last beyond it).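

Methoxy in place of hydrogen, on the aromatic carbon para to a large group, gives a 3.1-fold higher number from compound 3 to compound 4 (0.49 log units; beyond the scatter), so unlike the earlier small swaps, this change moves the number beyond the scatter. The swap of (4-methoxyphenyl)amino for 4-methoxyphenyl gives a 2.1-fold higher number from compound 1 to compound 4 (0.33 log units; beyond the scatter), while the swap for 4-(methylsulfanyl)phenyl stays within the scatter at a 1.7-fold higher number from compound 2 to compound 4 (0.24 log units; within the scatter). Nothing measured here gives a reason for these differences.

As far as these compounds go, whether fluoro, methyl or a dimethylamino group at this carbon would give a similar rise remains open, as does the effect of methoxy on the other carbons of that ring.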